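A few compounds are considered here, and "the series" means these few. Any claim that something is new, unique, unknown or untested is made for them only; others in the source may bear on it.

Of the compounds shown here, three of one family have been measured so far. Compound 1 `C[C@@H](NC(=O)Nc1cccc(F)c1F)c1ccccc1` and compound 3 `C[C@@H](NC(=O)Nc1cccc(C(F)(F)F)c1F)c1ccccc1` share a core; compound 3 carries trifluoromethyl in place of fluoro on an aromatic carbon. Compound 2 `C[C@@H](NC(=O)Nc1cc(F)ccc1F)c1ccccc1` has the same atoms as compound 1 joined differently, and the difference between the two cores is not broken down here. Compound 4 `C[C@@H](NC(=O)Nc1cc(C(F)(F)F)ccc1F)c1ccccc1` is not yet measured; it carries trifluoromethyl in place of fluoro on an aromatic carbon. The two changes are the same kind of change, with a different surrounding: in compound 3 the new group sits ortho to a fluoro group and meta to a large group, in compound 4 meta to a large group and para to a fluoro group.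

In an ADME assay on the whole organism with Oryza sativa as the target, tested at 0.1 uM (a lower number here means a stronger effect, a higher number a weaker effect of the compound at the concentration tested), compound 1 gives 100%, and compound 2 gives 100%. Compound 3 gives 99%, so that the move from compound 1 to compound 3 is a number 1 percentage points lower from compound 1 to compound 3 (within the scatter).

The step to compound 4 is expected to be a number 1 percentage points lower from compound 2 to compound 4 (within the scatter) in this assay, because a number 1 percentage points lower from compound 1 to compound 3 (within the scatter) was small. Compound 4 is therefore estimated at 99%, between 94% and 100%.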

Compound 4, a percentage reported as activity, at one concentration (the size of the read-out at that concentration, not a potency): 87%
Beside the measured number, compound 4's estimate is 12 percentage points above it; the measured number lies below the stated range.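

In this assay, putting trifluoromethyl in place of fluoro on the core of compound 2 gives a modest effect that stands out from the usual variation, with a step of a number 13 percentage points lower from compound 2 to compound 4 (beyond the scatter). On the core of compound 1, the same replacement gives a number 1 percentage points lower from compound 1 to compound 3 (within the scatter), yet the two steps cannot be told apart: the same change on two cores in this assay, a number 1 percentage points lower (within the scatter) from compound 1 to compound 3 and a number 13 percentage points lower (beyond the scatter) from compound 2 to compound 4, 12 percentage points apart, within the scatter of two such steps. The results therefore show a clear shift on one core only; they do not show that the core changes the outcome of this replacement, nor that the replacement carries over reliably from one core to the other, since each core offers just one pair and each read-out comes from a single concentration.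

The compounds shown leave open whether a further pair of cores would give steps that clearly differ. They also leave open how an amine, a carboxylic acid or a longer chain would behave on the aromatic carbon that carries trifluoromethyl in compound 4.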